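This account rests on a few compounds, and the source may have more. Where it says the series, first, only, none or still open, it means among the compounds named here.

Working notes on the series.

Of the compounds shown here, three have been measured in a functional assay on WI-38 VA13 cells (Homo sapiens) for cytotoxicity; on this read-out lower numbers stand for an effect already at smaller amounts and higher numbers for an effect only at larger amounts of compound. Compound 1 `O=C(Nc1nc2ccc(NC(=O)C3CCCO3)cc2s1)C1CCCCC1` gives 1.3 ug/mL. Among the compounds with values here, compound 2 `Cc1cc(C(=O)Nc2ccc3nc(NC(=O)C4CCCCC4)sc3c2)n(C)n1` gives 0.12 ug/mL; the step of an 11-fold lower number from compound 1 to compound 2 (1.03 log units; beyond the scatter) is the only one-place step in the set, and it falls at a different carbonyl from the one exchanged below. Compound 3 `CCOC(=O)Nc1nc2ccc(NC(=O)c3c(Cl)cccc3Cl)cc2s1` gives 0.0026 ug/mL and stands lowest of the three numbers: compound 2 is nearest with a higher number and compound 1 furthest, both gaps beyond the scatter.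

Compound 4 `CCNC(=O)Nc1nc2ccc(NC(=O)c3c(Cl)cccc3Cl)cc2s1` is not yet measured. It differs from compound 3 by ethylamino in place of ethoxy on a carbonyl carbon. Within the data shown here, no measured pair changes this carbonyl alone; the carbonyl in question carries a different group in each of compounds 1, 2 and 3, so no step there can be isolated, and the step of an 11-fold lower number from compound 1 to compound 2 (1.03 log units; beyond the scatter) offers no direct guide. The direction of the change is therefore open, and only a step of modest size, possibly within the scatter, is expected: a 1.9-fold higher number from compound 3 to compound 4 (0.28 log units; within the scatter).

In this assay compound 4 is estimated at 0.005 ug/mL, with a range from 0.001 ug/mL to 0.03 ug/mL.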

Compound 4, half-maximal effective concentration: 0.032 ug/mL
Beside the measured number, compound 4's estimate is 6.4-fold (0.81 log units) below it; measured number above the stated range.
By their numbers in this assay, from the lowest: compound 3; then compound 4; then compound 2; then compound 1.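

In this assay the carbonyl carbon bearing the amide-type nitrogen proves sensitive to a change that leaves the heavy-atom count unchanged: ethylamino in place of ethoxy gives a 12-fold higher number from compound 3 to compound 4 (1.09 log units; beyond the scatter), with oxygen exchanged for nitrogen and a hydrogen-bond donor gained. Within the data shown here, this is the first one-place step read at this carbonyl, and it is large and runs towards a higher number, whereas the only earlier step, an 11-fold lower number from compound 1 to compound 2 (1.03 log units; beyond the scatter), lies at the other carbonyl and runs towards a lower number, so each of the two carbonyls now has one step beyond the scatter, too few to support a pattern. No measurement at hand bears on why the number moves at this position.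

On these data alone, it remains open whether dimethylamino, which has no amide hydrogen on that nitrogen, or a longer chain such as propylamino would give a number nearer that of compound 3 or that of compound 4. Also open, as far as these compounds go, is whether the same exchange gives a step of this size when the other carbonyl carries oxolan-2-yl or 1,3-dimethyl-1H-pyrazol-5-yl.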